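Butyl in place of 3-hydroxyphenyl on the shared core

The source may hold more compounds than are shown below. What is called first, only, known or untested is meant among the compounds shown, and "the series" means these compounds.

Of the compounds shown here, three that share one core have been measured in a functional assay on A549 cells (Homo sapiens) for antiproliferative activity, read by MTT assay, with a stated time of 72 h; a lower number here means a stronger inhibitor, a higher number a weaker inhibitor. Compound 1 `O=C1O[C@H]([C@@H](O)Cn2cc(-c3ccc(Br)cc3)nn2)C(OCc2ccccc2)=C1OCc1ccccc1` gives 750 nM in this assay. Compound 2 `O=C1O[C@H]([C@@H](O)Cn2cc(-c3cccc(O)c3)nn2)C(OCc2ccccc2)=C1OCc1ccccc1` gives 59900 nM, the highest of the two numbers shown, and it is reached by the step of an 80-fold higher number from compound 1 to compound 2 (1.90 log units; beyond the scatter). Compound 3 `CCCCCc1ccc(-c2cn(C/C=C3\OC(=O)C(OCc4ccccc4)=C3OCc3ccccc3)nn2)cc1`, which carries its group through a different linker, reaches only a limit of the assay, > 100000 nM; this is the limit of > 100000 nM in this assay, at which 1 of the 3 values shown sits.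

Compound 4 `CCCCc1cn(C[C@H](O)[C@H]2OC(=O)C(OCc3ccccc3)=C2OCc2ccccc2)nn1` has not yet been measured. It differs from compound 2 by butyl in place of 3-hydroxyphenyl on an aromatic carbon. Among the compounds with values here, only one measured step touches the same position, the one from compound 1 to compound 2, and that step was large, so this position clearly matters for the number. Within the data shown here, no measured pair, however, exchanges an aromatic ring for a chain, so the direction of the new step rests on weak footing. Since compound 2 stands at the weaker end of the numbers shown, the change is expected to bring the number down somewhat, with the step of a 3.0-fold lower number from compound 2 to compound 4 (0.48 log units; beyond the scatter) expected in this assay. Compound 4 is therefore estimated at 20000 nM, within a wide range from 3000 nM to 100000 nM.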

Compound 4, half-maximal inhibitory concentration: 28600 nM
Compound 4: middle estimate off by 1.4-fold (0.16 log units), on the low side; the range from low to high includes it.
By their numbers in this assay, from the lowest: compound 1; then compound 4; then compound 2. At a limit, above all of these: compound 3.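

In this assay, butyl in place of 3-hydroxyphenyl on this aromatic carbon gives a 2.1-fold lower number from compound 2 to compound 4 (0.32 log units; beyond the scatter) as a modest step, so at this position a chain with no ring does not fall behind the 3-hydroxyphenyl group. Set against 4-bromophenyl, the same chain gives a 38-fold higher number from compound 1 to compound 4 (1.58 log units; beyond the scatter) as a large step, which shows what the earlier single step could not: of the three groups now compared on the shared core, 4-bromophenyl is the one that stands apart, while 3-hydroxyphenyl and butyl lie much closer together. Nothing measured here bears on the reason for either step.

The compounds shown leave open whether the standing of compound 1 depends on the bromine or on the ring that carries it, a question that unsubstituted phenyl, 4-chlorophenyl or 3-bromophenyl at this position would help to separate. They also leave open how a longer chain, or a butyl chain ending in an amine, would compare with butyl on the same aromatic carbon.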